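This account rests on a few compounds, and the source may have more. Where it says the series, first, only, none or still open, it means among the compounds named here.

Of the compounds shown here, three have so far been measured in a functional assay on HepG2 cells (Homo sapiens) for cytotoxicity, read by MTT assay, with a stated time of 24 h; a higher number here means a weaker inhibitor, a lower number a stronger inhibitor. Compound 1 `CN(C)CCN1CCN(CC(=O)Nc2ccc(-c3nc4cc(Cl)ccc4o3)cc2)CC1` gives 2640 nM. Compound 2 `CN(C)CCN1CCN(CC(=O)Nc2ccc(-c3nc4ccccc4o3)cc2)CC1` gives in this assay a number of 16300 nM. These two differ in a single place, (chloro in place of hydrogen on an aromatic carbon), and that change made a step of a 6.2-fold lower number from compound 2 to compound 1 (0.79 log units; beyond the scatter). Compound 3 `Cc1cc(-c2nc3ccccc3o2)ccc1NC(=O)CCl` is built on a different core; the difference between the cores of compound 2 and compound 3 is not broken down here. In this assay compound 3 gives 14800 nM, a number that stands close to that of compound 2 and well apart from that of compound 1.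

Compound 4 `Cc1cc(-c2nc3cc(Cl)ccc3o2)ccc1NC(=O)CCl` has not yet been measured. It differs from compound 3 in one place, (chloro in place of hydrogen on an aromatic carbon), which is the same change that leads from compound 2 to compound 1, made at the same place of the ring system, only on the core of compound 3. Whether a step seen on one core carries over to another cannot be known from a single pair, so the expectation rests on that one step alone. The step from compound 3 to compound 4 is expected to be a 4.2-fold lower number from compound 3 to compound 4 (0.63 log units; beyond the scatter) because the same change on the other core gave a 6.2-fold lower number from compound 2 to compound 1 (0.79 log units; beyond the scatter). Compound 4 is therefore estimated to give 3500 nM in this assay, with a likely range from 1500 nM to 10000 nM.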

Compound 4, half-maximal inhibitory concentration: 35000 nM
Estimate against measurement, compound 4: 10-fold (1.00 log units) below; the whole stated range lies below it.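

In this assay, chloro in place of hydrogen on an aromatic carbon gave a 2.4-fold higher number from compound 3 to compound 4 (0.37 log units; beyond the scatter), a step that runs the opposite way to a 6.2-fold lower number from compound 2 to compound 1 (0.79 log units; beyond the scatter). Set side by side, the two steps differ in direction as well as in size: the same change on two cores in this assay, a 6.2-fold lower number (0.79 log units; beyond the scatter) from compound 2 to compound 1 and a 2.4-fold higher number (0.37 log units; beyond the scatter) from compound 3 to compound 4, 15-fold (1.16 log units) apart, beyond the scatter of two such steps. This shows that in this series the effect of the change seen on one core could not be carried over to the other, but with a single pair on each core it does not show which feature of the two cores goes with the reversal, or how the change would behave on any further core.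

The compounds shown leave open which of the differences between the two cores matters, since no pair separates them one at a time. They also leave open whether fluoro or bromo in place of the chloro would follow either step, and whether the reversal would persist with a simple acetamide in place of the side chains carried by these compounds.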